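The source may hold more compounds than are shown below. What is called first, only, known or untested is meant among the compounds shown, and "the series" means these compounds.

Measured compounds in a functional assay on K562 cells (Homo sapiens) for cytotoxicity, read by sulforhodamine B assay, with a stated time of 48 h; a lower number here means a stronger inhibitor of growth, a higher number a weaker inhibitor of growth:
Compound 1 `Cc1cnc(NC(=O)COc2ccc(/C=C3\SC(=O)NC3=O)cc2)s1` gives < 100000 nM, which is a limit of this assay rather than a number.
Compound 2 `CCCCC1=NC2(CCCC2)C(=O)N1C(=O)COc1ccc(/C=C2/SC(=O)NC2=O)cc1` gives < 100000 nM, also a limit.
Compound 3 `O=C(COc1ccc(/C=C2\SC(=O)NC2=O)cc1)Nc1cccc(C(F)(F)F)c1` gives < 100000 nM, again a limit.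

Because all three values sit at the limit of < 100000 nM in this assay, at which 3 of the 3 values shown sit, compound 1 cannot be placed above or below the others; its position on the scale is only a limit. Compound 4 `O=C(COc1ccc(/C=C2\SC(=O)NC2=O)cc1)Nc1ccccn1` differs from compound 1 in one place: pyridin-2-yl in place of 5-methyl-1,3-thiazol-2-yl on an amide-type nitrogen. Within the data shown here, no step between measured compounds exists here, so nothing measured tells how large a change this replacement brings. The expectation for compound 4 is 30000 nM, with a range from 5000 nM to 100000 nM. The step that the limit leaves unreadable from compound 1 to compound 4 is expected to stay within the scatter.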

Compound 4, concentration for total growth inhibition: < 100000 nM
Compound 4 gave a limit, no number; the forecaster's own chance of this, stated with the estimate: 70%; the middle value does not contradict the limit.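

No step can be read between compound 1 and compound 4 because both values are only limits: the limit of < 100000 nM in this assay, at which 4 of the 4 values shown sit. The compounds shown leave open how strongly each inhibits growth, and whether pyridin-2-yl and 5-methyl-1,3-thiazol-2-yl differ at all.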